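A few compounds are considered here, and "the series" means these few. Any claim that something is new, unique, unknown or untested is made for them only; others in the source may bear on it.

Three compounds have been measured in an ADME assay on HEL cells (Homo sapiens) for cytotoxicity, with a stated time of 3 days; on this read-out lower numbers stand for higher toxicity in this test and higher numbers for lower toxicity in this test:

Compound 1 `CCC1(Cc2ccccc2)OS(=O)(=O)C=C1OCc1ccc(F)cc1`: > 50000 nM
Compound 2 `CCC1(Cc2ccccc2)OS(=O)(=O)CC1=O`: 200000 nM
Compound 3 `CC(C)CC1(Cc2ccccc2)OS(=O)(=O)C=C1OCc1ccccc1`: 102000 nM

Compound 1 stands at the limit of > 50000 nM in this assay, at which 1 of the 3 values shown sits; this is a limit of the assay rather than a measured number. Compound 2 and compound 3 give numbers above that limit, and both lie in the region of low toxicity. No pair among these three differs in just one place, so no measured step is available to lean on.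

Compound 4 `CCC1(Cc2ccccc2)OS(=O)(=O)C=C1OCc1ccc(Br)cc1` differs from compound 1 by bromo in place of fluoro on an aromatic carbon. For the measured compounds named here, with only a limit for compound 1 and no measured step, the step to compound 4 is expected to be none beyond the scatter, in either direction. Compound 4 is expected at 100000 nM, with a range from 40000 nM to 250000 nM. The expected step that the limit leaves unreadable from compound 1 to compound 4 is therefore small.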

Compound 4, half-maximal cytotoxic concentration: 171000 nM
Compound 4: middle estimate off by 1.7-fold (0.23 log units), on the low side; measured number inside the range.
By their numbers in this assay, from the lowest: compounds 3, 4 and 2 (each within the scatter of the next).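

For the compounds shown here, no step from compound 1 to compound 4 can be read, because compound 1 carries only a limit and not a number: the limit of > 50000 nM in this assay, at which 1 of the 4 values shown sits. On these data alone, whether bromo in place of fluoro changes the toxicity reading at all, and in which direction, stays open.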